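The source may hold more compounds than are shown below. What is called first, only, known or untested is meant among the compounds shown, and "the series" means these compounds.

Working notes on the series. In an assay on isolated protein for binding affinity to Equilibrative nucleoside transporter 1 (Homo sapiens) (on this read-out lower numbers stand for stronger inhibition and higher numbers for weaker inhibition), compound 1 `O=[N+]([O-])c1cccc2c1CCN(c1ncnc3c1nc1n3[C@@H]3O[C@H](CO1)[C@@H](O)[C@H]3O)C2` gives 7410000 nM, compound 2 `Nc1nc(SCc2ccc(Br)cc2)c2ncn([C@@H]3O[C@H](CO)[C@@H](O)[C@H]3O)c2n1` gives 813 nM, and compound 3 `Cc1cc(C)c(SCc2ncnc3c2ncn3[C@@H]2O[C@H](CO)[C@@H](O)[C@H]2O)c(C)c1` gives 33100 nM. Compound 3 thus holds the second highest of the three numbers: its value sits well below that of compound 1 and well above that of compound 2, both gaps lying beyond the scatter. Compound 4 `COc1ccc(SCc2ncnc3c2ncn3[C@@H]2O[C@H](CO)[C@@H](O)[C@H]2O)cc1` is not yet measured; it differs from compound 3 by 4-methoxyphenyl in place of 2,4,6-trimethylphenyl on a sulfur. Among the compounds with values here, no measured pair shows this change, so its effect is open. A modest step downward is expected, a 2.8-fold lower number from compound 3 to compound 4 (0.44 log units; beyond the scatter), not far beyond the scatter. For compound 4 the value in this assay is estimated at 12000 nM, with a range from 2500 nM to 60000 nM.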

Compound 4, half-maximal inhibitory concentration: 617 nM
Compound 4: the middle estimate sits 19-fold (1.29 log units) above what was measured; measured number below the stated range.
By their numbers in this assay, from the lowest: compounds 4 and 2 (each within the scatter of the next); then compound 3; then compound 1.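

Within the data shown here, the group on the sulfur carries far more weight in this assay than the earlier compounds could show: the change of 2,4,6-trimethylphenyl to 4-methoxyphenyl gives a 54-fold lower number from compound 3 to compound 4 (1.73 log units; beyond the scatter), although both groups hold one six-membered aromatic ring of carbon only. The entering group differs in its oxygen and its hydrogen-bond acceptor, but nothing available explains the step. Still open, from the compounds shown here alone, is whether the methoxy group or the loss of the three methyl groups drives it. A plain phenyl or a 4-methylphenyl on the sulfur would separate the two.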